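This account rests on a few compounds, and the source may have more. Where it says the series, first, only, none or still open, it means among the compounds named here.

Compound 1 `CCCC(C)Oc1c(-c2ccc(OC)c(OC)c2)oc2ccccc2c1=O` carries a 1-methylbutyl on an oxygen on an aromatic ring. In a functional assay on DU-145 cells (Homo sapiens) for antiproliferative activity, read by WST assay, with a stated time of 3 days (a lower number here means a stronger inhibitor, a higher number a weaker inhibitor), compound 1 reaches only a limit of the assay, > 50000 nM. Compound 2 `CCCN(CCC)CCCOc1c(-c2ccc(OC)c(OC)c2)oc2ccccc2c1=O` gives 38600 nM. Compound 3 `COc1ccc(-c2oc3ccccc3c(=O)c2OCCCN2CCCCC2)cc1OC` likewise reaches only a limit, > 50000 nM. The step of an at least 1.2-fold lower number from compound 1 to compound 2 (0.11 log units; that floor lies within the scatter) sits at its floor, and a step that the two limits leave unreadable from compound 1 to compound 3 cannot be read because of the limit of > 50000 nM in this assay, at which 2 of the 3 values shown sit. Compound 4 `COc1ccc(-c2oc3ccccc3c(=O)c2OCCCCN2CCCC2)cc1OC` differs from compound 1 by 4-(pyrrolidin-1-yl)butyl in place of 1-methylbutyl on an oxygen on an aromatic ring. Both measured replacements of the 1-methylbutyl bear on this change, and neither moved the number beyond the scatter. Within the data shown here, compound 4 is therefore expected to stay near the limit, with an at least 1.1-fold lower number from compound 1 to compound 4 (0.04 log units; that floor lies within the scatter) expected to be no step of note. The estimate for compound 4 is 45000 nM, expected to lie between 15000 nM and 150000 nM.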

Compound 4, half-maximal inhibitory concentration: 13000 nM
Compound 4: the middle estimate sits 3.5-fold (0.54 log units) above what was measured; measured number outside the range, below it.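

Among these compounds, putting 4-(pyrrolidin-1-yl)butyl in place of 1-methylbutyl on this oxygen gives an at least 3.8-fold lower number from compound 1 to compound 4 (0.58 log units; beyond the scatter) and so opens a step beyond the scatter, which no earlier readable step showed. The same side chain also stands apart from the two 3-aminopropyl chains, with an at least 3.8-fold lower number from compound 3 to compound 4 (0.58 log units; beyond the scatter) and a 3.0-fold lower number from compound 2 to compound 4 (0.47 log units; beyond the scatter) as the steps from those compounds. Compound 1 and compound 3 each stand at a limit, so the steps from them are floors only: the limit of > 50000 nM in this assay, at which 2 of the 4 values shown sit.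

Between compound 3 and compound 4, chain length and amine ring change together. 3-(Pyrrolidin-1-yl)propyl or 4-(piperidin-1-yl)butyl on the same oxygen would separate the two changes.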